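Swapping the aryl group on an ethyl-bearing core

The compounds below may be only part of what the source reports. "The series", "measured", "known", "first", "only" and "open" are said of these compounds alone.

Measured compounds:
Compound 1 `Cc1nc(-c2ccc(F)cc2)c(C(=O)N2CCN(c3cccc(Cl)c3)CC2)o1`: 40.1 nM
Compound 2 `Cc1nc(-c2ccccc2Cl)c(C(=O)N2CCN(c3cccc(Cl)c3)CC2)o1`: 132 nM
Compound 3 `CCc1nc(-c2ccc(F)cc2)c(C(=O)N2CCN(c3cccc(Cl)c3)CC2)o1`: 169 nM

These three compounds were tested in a functional assay on HL-60 cells (Homo sapiens) for inhibition, read by MTT assay, with a stated time of 72 h; on this read-out higher numbers stand for weaker inhibition and lower numbers for stronger inhibition. Compound 4 `CCc1nc(-c2ccccc2Cl)c(C(=O)N2CCN(c3cccc(Cl)c3)CC2)o1` has not yet been measured in this assay. Compound 1 and compound 3 differ in the following way: methyl in place of hydrogen on a saturated chain carbon bound to an aromatic carbon. This change made a step of a 4.2-fold higher number from compound 1 to compound 3 (0.62 log units; beyond the scatter). Compound 4 is built from compound 3 by the change (2-chlorophenyl in place of 4-fluorophenyl on an aromatic carbon). The same kind of change has already been made once, from compound 1 to compound 2: 2-chlorophenyl in place of 4-fluorophenyl on an aromatic carbon. There it made a step of a 3.3-fold higher number from compound 1 to compound 2 (0.52 log units; beyond the scatter). The two changes are of the same kind but not the same, since the surroundings differ: in one case the ring atom two ring bonds away bears a methyl group, in the other an ethyl group. If the step repeats, compound 4 is expected to reach about 520 nM, a step of a 3.1-fold higher number from compound 3 to compound 4 (0.49 log units; beyond the scatter), because the earlier step was a 3.3-fold higher number from compound 1 to compound 2 (0.52 log units; beyond the scatter). Among the compounds with values here, with only one example, the expected range for compound 4 is wide, from 200 nM to 1400 nM.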

Compound 4, half-maximal inhibitory concentration: 98.9 nM
The estimate for compound 4 lay 5.3-fold (0.72 log units) above the measured number; measured number outside the range, below it.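

On the ethyl-bearing core, the swap from 4-fluorophenyl to 2-chlorophenyl gave a 1.7-fold lower number from compound 3 to compound 4 (0.23 log units; within the scatter) in this assay, so these two compounds cannot be told apart, and the rise seen on the methyl-bearing core did not carry over: the same change on two cores in this assay, a 3.3-fold higher number (0.52 log units; beyond the scatter) from compound 1 to compound 2 and a 1.7-fold lower number (0.23 log units; within the scatter) from compound 3 to compound 4, 5.6-fold (0.75 log units) apart, beyond the scatter of two such steps

Going from methyl to ethyl with 2-chlorophenyl in place gave a 1.3-fold lower number from compound 2 to compound 4 (0.13 log units; within the scatter), so that change also failed to repeat what it did with 4-fluorophenyl: the same change on two cores in this assay, a 4.2-fold higher number (0.62 log units; beyond the scatter) from compound 1 to compound 3 and a 1.3-fold lower number (0.13 log units; within the scatter) from compound 2 to compound 4, 5.6-fold (0.75 log units) apart, beyond the scatter of two such steps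

The size of each change therefore depends on what else the core carries, so a step seen on one core is a poor guide to the same step on another in this series, although four compounds cannot show why this happens or how general it is.

The compounds shown leave open how a plain phenyl group would behave on these two cores. They also leave open whether a propyl chain on the ring atom that bears the ethyl group would follow the same pattern.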